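Moving the bromine on compound 3's benzoyl ring

A few compounds are considered here, and "the series" means these few. Any claim that something is new, unique, unknown or untested is made for them only; others in the source may bear on it.

Measured compounds:
compound 1 `CC(C)(C)N(NC(=O)c1ccccc1)C(=O)c1ccccc1I`: 105 nM
compound 2 `Cc1cc(C)cc(C(=O)N(NC(=O)c2ccccc2)C(C)(C)C)c1`: 69.2 nM
compound 3 `CC(C)(C)N(NC(=O)c1ccccc1Br)C(=O)c1ccccc1Cl`: 316 nM

In an assay on cells for agonist activity at ecdysone receptor (Bombyx mori), read by a luciferase reporter, with a stated time of 24 h (on this read-out lower numbers stand for an effect already at smaller amounts and higher numbers for an effect only at larger amounts of compound), compound 3 gives 316 nM, the highest number of the three; compound 1 gives 105 nM and compound 2 gives 69.2 nM, both beyond the scatter from compound 3. Compound 4 `CC(C)(C)N(NC(=O)c1ccc(Br)cc1)C(=O)c1ccccc1Cl` differs from compound 3 only by 4-bromophenyl in place of 2-bromophenyl on a carbonyl carbon. Among the measured compounds shown here, no measured step concerns this change: the only step, a 1.5-fold lower number from compound 1 to compound 2 (0.18 log units; within the scatter), alters the other carbonyl substituent and stays within the scatter. Because compound 3 gives 316 nM, the weakest start here, a modest move toward the other two seems plausible, though the data give no direct support. Compound 4 is expected at 150 nM, between 40 nM and 600 nM, a step of a 2.1-fold lower number from compound 3 to compound 4 (0.32 log units; beyond the scatter).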

Compound 4, half-maximal effective concentration: 33.9 nM
Estimate against measurement, compound 4: 4.4-fold (0.65 log units) above, outside the stated range (below it).
By their numbers in this assay, from the lowest: compound 4; then compounds 2 and 1 (each within the scatter of the next); then compound 3.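

In this assay, moving the bromine alone, with 4-bromophenyl in place of 2-bromophenyl on a carbonyl carbon, gives a 9.3-fold lower number from compound 3 to compound 4 (0.97 log units; beyond the scatter). Among the compounds shown here, the earlier step concerned only the other carbonyl substituent, so this is the first sign that the read-out responds to where the bromine sits, though the two compounds hold the same atoms. Nothing available explains this difference. Going by these compounds, it stays open whether an amine or a carboxylic acid in place of the bromine of compound 4 would keep this low number.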